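Aryl enone series: methylsulfanyl in place of tert-butyl

The source may report more compounds than this note shows. Statements on the series, on what has been measured and on what is new or still open speak of the compounds shown alone.

Compound 1 `CC(C)(C)c1ccc(C(=O)/C=C/c2ccncc2)cc1` is the reference point of the set. In a functional assay with Rattus norvegicus as the target (a lower number here means a stronger inhibitor, a higher number a weaker inhibitor), compound 1 gives 47000 nM, the lowest of the two numbers available. Compound 2 `O=c1cc(-c2cccnc2)oc2ccccc12` gives about 100000 nM in this assay, a number that lies beyond the scatter above that of compound 1. Compound 3 `CO/N=C(\C=C\c1ccncc1)c1cc(OC)c(OC)c(OC)c1` returns only a limit of this assay, > 100000 nM, and not a number; this is the limit of > 100000 nM in this assay, at which 1 of the 3 values shown sits. Among the compounds with values here, no pair of measured compounds differs in a single place, so no measured step is available to read the series from.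

Compound 4 `CSc1ccc(C(=O)/C=C/c2ccncc2)cc1` is the next compound to be measured in this assay. It differs from compound 1 by methylsulfanyl in place of tert-butyl on an aromatic carbon. The rest of the core of compound 1 is kept. Within the data shown here, with no measured step at this place, the expectation rests on compound 1 alone. The expected step is a 1.1-fold higher number from compound 1 to compound 4 (0.03 log units; within the scatter), none beyond the scatter. Compound 4 is therefore estimated at 50000 nM, with a range from 15000 nM to 150000 nM.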

Compound 4, half-maximal inhibitory concentration: 33000 nM
Compound 4: middle estimate off by 1.5-fold (0.18 log units), on the high side; measured number inside the range.
By their numbers in this assay, from the lowest: compounds 4 and 1 (each within the scatter of the next); then compound 2.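

In this assay, within the data shown here, methylsulfanyl in place of tert-butyl gives a 1.4-fold lower number from compound 1 to compound 4 (0.15 log units; within the scatter) at this aromatic carbon, the first measured step. The two compounds therefore cannot be told apart here, although the group changes from 4 heavy atoms, all carbon, to 2 heavy atoms, one of them sulfur, and gains a hydrogen-bond acceptor. No measurement shown gives a reason why the two groups read alike.

From the compounds shown here alone, whether any group at this aromatic carbon can move the number beyond the scatter remains open, as this one step stays within it. An amine, a carboxylic acid or a longer chain in the same place would show how far the reading holds.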